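The source may hold more compounds than are shown below. What is called first, only, known or untested is meant among the compounds shown, and "the series" means these compounds.

The series rests on a shared core, seen in compound 1 `N#C/C(=C\c1c(-c2ccccc2)[nH]c2ccccc12)C(=O)c1ccccc1`. In a functional assay on NCI-H226 cells (Homo sapiens) for inhibition, read by sulforhodamine B assay, with a stated time of 48 h (on this read-out lower numbers stand for stronger inhibition of growth and higher numbers for weaker inhibition of growth), compound 1 gives 6800 nM. Two companions were measured beside it. Compound 2 `CCOC(=O)C(=Cc1c(-c2ccccc2)[nH]c2ccccc12)C(=O)OCC`, which carries two ester arms on the chain, gives 11400 nM in this assay; these two values of compound 1 and compound 2 sit within the scatter of one another, so no order between them can be read. Compound 3 `COc1ccc(-c2[nH]c3ccc(OC)cc3c2C=C(C#N)C#N)cc1`, with two nitriles on the chain and methoxy groups on both rings, gives 1500 nM; its number lies well below that of compound 1, beyond the scatter, so compound 1 stands second highest among the three.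

Compound 4 `N#C/C(=C\c1c(-c2ccccc2)[nH]c2ccccc12)S(=O)(=O)c1ccccc1` has not yet been measured. It differs from compound 1 by a single change: phenylsulfonyl in place of benzoyl on a double-bonded chain carbon bound to a double-bonded chain carbon and a triple-bonded carbon. Within the data shown here, no step between measured compounds matches this change, so the direction of its effect is open. Given that compound 1 gives 6800 nM and the two ester arms of compound 2 left the number within the scatter, compound 4 is expected to stay near compound 1, with a step of a 1.2-fold lower number from compound 1 to compound 4 (0.09 log units; within the scatter) that is not expected to pass beyond the scatter. Compound 4 is estimated at 5500 nM, with a range from 1800 nM to 17000 nM.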

Compound 4, concentration for 50% growth inhibition: 4100 nM
The estimate for compound 4 lay 1.3-fold (0.13 log units) above the measured number; measured number inside the range.
By their numbers in this assay, from the lowest: compound 3; then compounds 4, 1 and 2 (each within the scatter of the next, the first and the last beyond it).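

Among these compounds, compound 4 gives the first comparison in this set that differs in one place only. In this assay, phenylsulfonyl in place of benzoyl on a double-bonded chain carbon bound to a double-bonded chain carbon and a triple-bonded carbon gives a 1.7-fold lower number from compound 1 to compound 4 (0.22 log units; within the scatter), so no order between the two compounds can be read, and this position carries either group without a change that stands clear of the scatter. Nothing at hand accounts for how closely the two compounds read.

The compounds shown leave open how an amine or a carboxylic acid on this same chain carbon would read, and whether any group there could move the number beyond the scatter. They also leave open how far the methoxy groups on both rings of compound 3 and its second nitrile each bear on growth inhibition, as these features are not separated from one another in any single step.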